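The compounds below may be only part of what the source reports. "The series", "measured", "known", "first", "only" and "open" are said of these compounds alone.

Working notes on the series in a functional assay on HeLa cells (Homo sapiens) for cytotoxicity, read by XTT assay, with a stated time of 72 h; a lower number here means a stronger inhibitor, a higher number a weaker inhibitor. Compound 1 `CCCCCCCCCCCCCCCCCCc1c(O)cc(O)c(C(C)=O)c1O` gives 26000 nM. Compound 2 `C=C1CC[C@H]2C(C)(C)CCC[C@]2(C)[C@H]1CC/C(C)=C/Cc1c(O)cc(O)c2c(=O)c(O)c(-c3ccc(O)cc3)oc12` gives 30000 nM, within the scatter of compound 1, so no order can be drawn between the two. Compound 3 `CC(C)=CCC/C=C(\C)Cc1c(OC/C=C(\C)CCC=C(C)C)cc(O)c2c(=O)cc(-c3ccccc3)oc12` gives only a limit of the assay, > 100000 nM.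

The next compound to be read is compound 4 `CCCCCCCC/C=C\CCCCCCCCc1c(O)cc(O)c(C(C)=O)c1O`. Its change from compound 1 is dec-1-en-1-yl in place of decyl on a saturated chain carbon, eight bonds along the chain from an aromatic carbon.

Among the measured compounds shown here, no measured pair differs in one place, so the size of this step in this assay has no direct precedent. The expectation is no change beyond the scatter, in either direction, and it rests only on compound 1 at 26000 nM. The estimated step is a 1.3-fold lower number from compound 1 to compound 4 (0.11 log units; within the scatter). For compound 4 the expected value is 20000 nM, with an estimated range of 8000 nM to 50000 nM.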

Compound 4, half-maximal inhibitory concentration: > 100000 nM
Compound 4: a limit, no number; the forecaster's own chance of this, stated with the estimate: 10%; middle value at least 5.0-fold (0.69 log units) from the limit.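

Placing dec-1-en-1-yl in place of decyl, on a saturated chain carbon, eight bonds along the chain from an aromatic carbon, gives the first single-place step in this assay: an at least 3.8-fold higher number from compound 1 to compound 4 (0.58 log units; beyond the scatter). Compound 4 gives only a limit of the assay, > 100000 nM, so the step has a lower bound and no full size, because the reading ends at the ceiling of the assay: the limit of > 100000 nM in this assay, at which 2 of the 4 values shown sit. Among the compounds shown here, as counted, the two groups differ by one double bond outside aromatic rings, so this position does respond to a change that small, which the earlier compounds could not show.

Going by these compounds, whether the step belongs to the double bond as such or to this place along the chain stays open. Also open, on these data alone, is how a longer chain, an amine or a carboxylic acid in place of decyl would read.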